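A Sulfonyl Linker Replaces the Amide in a Pyrazoline Series

A few compounds are considered here, and "the series" means these few. Any claim that something is new, unique, unknown or untested is made for them only; others in the source may bear on it.

Of the compounds shown here, two built on the same core have been tested. Compound 1 `CN(C)c1ccc(C2CC(c3ccc(-n4cncn4)cc3)=NN2C(=O)c2ccc(F)cc2)cc1` carries a 4-fluorophenyl group on its carbonyl carbon; in a functional assay on NCI-H1975 cells (Homo sapiens) for inhibition, read by sulforhodamine B assay, tested at 10 uM (on this read-out higher numbers stand for more inhibition at the one concentration tested (going by the name of the read-out) and lower numbers for less inhibition), compound 1 gives -1.1%. Compound 2 `CN(C)c1ccc(C2CC(c3ccc(-n4cncn4)cc3)=NN2C(=O)c2cc(Cl)cc(Cl)c2)cc1` carries a 3,5-dichlorophenyl group in that place instead, and in this assay compound 2 gives 8.4%. Within the data shown here, the one measured step, a number 9.5 percentage points higher from compound 1 to compound 2 (within the scatter), stays within the usual scatter, so the two values cannot be told apart. Compound 2 holds the higher of the two numbers, but only by a margin that repeated testing could erase.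

Compound 3 `CN(C)c1ccc(C2CC(c3ccc(-n4cncn4)cc3)=NN2S(=O)(=O)c2ccc(F)cc2)cc1` is not yet measured. It differs from compound 2 in one place: (4-fluorophenyl)sulfonyl in place of (3,5-dichlorophenyl)carbonyl on an amine nitrogen in a ring. Among the measured compounds shown here, the step from compound 1 to compound 2 bears on this change only in part, since it swapped the aromatic ring while keeping the carbonyl; no measured pair exchanges a carbonyl for a sulfonyl. For the measured compounds named here, with both known values near zero and the one known step within the scatter, no movement beyond the scatter is expected for compound 3, and the step of a number 4.4 percentage points lower from compound 2 to compound 3 (within the scatter) is estimated to be small. Compound 3 is expected to give about 4% in this assay, within a range from -15% to 25%.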

Compound 3, a percentage reported as inhibition, at one concentration (the size of the read-out at that concentration, not a potency): -0.5%
For compound 3 the middle estimate is 4.5 percentage points above the measured one; measured number inside the range.
By their numbers in this assay, from the lowest: compounds 1, 3 and 2 (each within the scatter of the next).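

Among these compounds, compound 1 and compound 3 both carry the 4-fluorophenyl group, so this pair gives the first direct reading of a sulfonyl against a carbonyl on the amine nitrogen in a ring: in this assay the exchange amounts to a number 0.6 percentage points higher from compound 1 to compound 3 (within the scatter) and nothing that can be told apart. The exchange that replaces the linker and the aromatic ring together, a number 8.9 percentage points lower from compound 2 to compound 3 (within the scatter) as well, also leaves the two numbers indistinguishable, so all three groups on this nitrogen give values that repeated testing could not separate. No measurement shown here offers an explanation for these values.

From the compounds shown here alone, what stays open is whether a smaller acetyl group or a longer alkyl chain on this nitrogen would lift the number clear of the scatter, and whether a carboxylic acid or an amine in place of the 4-(dimethylamino)phenyl group would do so. A (3,5-dichlorophenyl)sulfonyl group would also complete the set, although a linker comparison can only become informative in a compound whose inhibition stands well clear of the scatter.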